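The compounds below may be only part of what the source reports. "The series", "measured", "known", "first", "only" and "open" are said of these compounds alone.

Measured so far in a functional assay on L1210 cells (Mus musculus); on this read-out lower numbers stand for stronger inhibition and higher numbers for weaker inhibition:

Compound 1 `CCC#Cc1cn([C@H]2C[C@H](O)[C@@H](CO)O2)c(=O)[nH]c1=O` gives > 1000 ug/mL, which is a limit of this assay and not a number.
Compound 2 `CCCCCC#Cc1cn([C@H]2C[C@H](O)[C@@H](CO)O2)c(=O)[nH]c1=O` gives 219 ug/mL.
Compound 3 `O=c1[nH]c(=O)n([C@H]2C[C@H](O)[C@@H](CO)O2)cc1C#Cc1ccccc1` gives 494 ug/mL.

Compound 3 holds the highest of the two numbers shown; the gap to the other number is modest, as a 2.3-fold higher number from compound 2 to compound 3 (0.35 log units; beyond the scatter) shows. Compound 4 `CC#Cc1cn([C@H]2C[C@H](O)[C@@H](CO)O2)c(=O)[nH]c1=O` differs from compound 3 by methyl in place of phenyl on a triple-bonded carbon. Going by the values given here, two measured steps concern the group on the triple-bonded carbon: an at least 2.0-fold lower number from compound 1 to compound 3 (0.30 log units; that floor lies within the scatter) and a 2.3-fold higher number from compound 2 to compound 3 (0.35 log units; beyond the scatter). A longer chain there helped, since an at least 4.5-fold lower number from compound 1 to compound 2 (0.65 log units; beyond the scatter); a methyl is shorter still than the ethyl of compound 1, whose result was only (the limit of > 1000 ug/mL in this assay, at which 1 of the 3 values shown sits). Compound 4 is therefore expected to give a higher number than compound 3, most likely again only a limit; the expected step is a 3.0-fold higher number from compound 3 to compound 4 (0.48 log units; beyond the scatter). The estimate for compound 4 is 1500 ug/mL, between 500 ug/mL and 5000 ug/mL.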

Compound 4, concentration for 50% inhibition: 164 ug/mL
Compound 4: middle estimate off by 9.1-fold (0.96 log units), on the high side, outside the stated range (below it).
By their numbers in this assay, from the lowest: compounds 4 and 2 (each within the scatter of the next); then compound 3. At a limit, above all of these: compound 1.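

In this assay, methyl in place of phenyl on the triple-bonded carbon gives a 3.0-fold lower number from compound 3 to compound 4 (0.48 log units; beyond the scatter), so the much smaller group does better here than the aromatic ring. Chain length sets no simple trend: methyl and pentyl cannot be told apart, with a 1.3-fold lower number from compound 2 to compound 4 (0.13 log units; within the scatter), while compound 1, with its ethyl, goes against any steady trend, as an at least 6.0-fold lower number from compound 1 to compound 4 (0.78 log units; beyond the scatter) shows. Compound 1 remains a limit, not a number: the limit of > 1000 ug/mL in this assay, at which 1 of the 4 values shown sits.

From the compounds shown here alone, whether butyl, or a chain longer than pentyl, would behave like ethyl or like methyl and pentyl stays open. The compounds shown also cannot tell why methyl and ethyl part so far.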